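A few compounds are considered here, and "the series" means these few. Any claim that something is new, unique, unknown or untested is made for them only; others in the source may bear on it.

Three compounds in this series share one core and differ only in the aryl group on the five-membered ring. In a functional assay on Caco-2 cells (Homo sapiens) for cytotoxicity, with a stated time of 48 h (on this read-out lower numbers stand for stronger inhibition and higher numbers for weaker inhibition), compound 1 `O=[N+]([O-])c1ccc(CN2CCC(n3cc(CC(OCc4cc(-c5ccc(Br)cc5)no4)c4ccc(Br)cc4)nn3)CC2)cc1` gives 3000 nM, compound 2 `N#Cc1ccc(-c2cc(COC(Cc3cn(C4CCN(Cc5ccc([N+](=O)[O-])cc5)CC4)nn3)c3ccc(Br)cc3)on2)cc1` gives 2000 nM, and compound 3 `COc1cccc(-c2cc(COC(Cc3cn(C4CCN(Cc5ccc([N+](=O)[O-])cc5)CC4)nn3)c3ccc(Br)cc3)on2)c1` gives 5000 nM. Compound 3 thus carries the highest of the three numbers in this assay; its nearest neighbour is compound 1, with a 1.7-fold higher number from compound 1 to compound 3 (0.22 log units; within the scatter), while the step of a 2.5-fold higher number from compound 2 to compound 3 (0.40 log units; beyond the scatter) is the only one to reach beyond the scatter, and even that is modest.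

Compound 4 `O=[N+]([O-])c1ccc(CN2CCC(n3cc(CC(OCc4cc(-c5ccccc5F)no4)c4ccc(Br)cc4)nn3)CC2)cc1` takes the next step: 2-fluorophenyl in place of 3-methoxyphenyl on an aromatic carbon. Both measured steps that bear on it, a 1.7-fold higher number from compound 1 to compound 3 (0.22 log units; within the scatter) and a 2.5-fold higher number from compound 2 to compound 3 (0.40 log units; beyond the scatter), exchanged the aryl group at this very place, and both were small, so exchanging it once more is expected to move this assay by little. The estimate for compound 4 is therefore 3500 nM, within a range of 1400 nM to 9000 nM, which would mean an expected step of a 1.4-fold lower number from compound 3 to compound 4 (0.15 log units; within the scatter); because the step of a 2.5-fold higher number from compound 2 to compound 3 (0.40 log units; beyond the scatter) ran upward while a 1.7-fold higher number from compound 1 to compound 3 (0.22 log units; within the scatter) stayed within the scatter, the expected direction is a slightly lower number, without confidence that it clears the scatter.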

Compound 4, half-maximal inhibitory concentration: 4000 nM
Beside the measured number, compound 4's estimate is 1.1-fold (0.06 log units) below it, within the range that was stated.
By their numbers in this assay, from the lowest: compounds 2, 1, 4 and 3 (each within the scatter of the next, the first and the last beyond it).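

With 2-fluorophenyl on this aromatic carbon of the five-membered ring, next to the ring nitrogen, compound 4 cannot be separated from any earlier compound in this assay: the steps are a 1.3-fold lower number from compound 3 to compound 4 (0.10 log units; within the scatter), a 1.3-fold higher number from compound 1 to compound 4 (0.12 log units; within the scatter) and a 2.0-fold higher number from compound 2 to compound 4 (0.30 log units; within the scatter). The earlier compounds had shown one step past the scatter at this place, a 2.5-fold higher number from compound 2 to compound 3 (0.40 log units; beyond the scatter), and compound 4 does not widen that spread, since its number falls within the scatter of both of those compounds. The place therefore now carries four different substituted phenyl groups, bearing bromo, cyano, methoxy or fluoro, and only compound 2 and compound 3 stand apart, with no information here on what lies behind that small spread.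

From the compounds shown here alone, all four compounds keep a substituted phenyl ring at this place, so it remains open how this assay would respond to an amine, a carboxylic acid or a longer alkyl chain there. Going by these compounds, it also remains open whether an unsubstituted phenyl or a saturated ring such as cyclohexyl would stay within the same narrow span.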